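Para halogen swap on the benzylidene hydrazide of compound 3

This account rests on a few compounds, and the source may have more. Where it says the series, first, only, none or still open, it means among the compounds named here.

Measured compounds:
compound 1 `O=C(CSc1nnc(-c2ccncc2)n1-c1ccccc1)N/N=C/c1ccccc1` gives 14700 nM
compound 2 `COc1ccc(/C=N/NC(=O)CSc2nnc(-c3ccncc3)n2-c2ccccc2)cc1` gives 19200 nM
compound 3 `O=C(CSc1nnc(-c2ccncc2)n1-c1ccccc1)N/N=C/c1ccc(Br)cc1` gives 4500 nM

Three hydrazide analogues sharing one core were tested in a functional assay on HCT-116 cells (Homo sapiens) for inhibition, read by MTT assay, with a stated time of 48 h; a lower number here means a stronger inhibitor, a higher number a weaker inhibitor. Among them compound 3 stands lowest: the step of a 3.3-fold lower number from compound 1 to compound 3 (0.51 log units; beyond the scatter) and the step of a 4.3-fold lower number from compound 2 to compound 3 (0.63 log units; beyond the scatter) both lie beyond the scatter, whereas the step of a 1.3-fold higher number from compound 1 to compound 2 (0.12 log units; within the scatter) does not. Compound 4 `O=C(CSc1nnc(-c2ccncc2)n1-c1ccccc1)N/N=C/c1ccc(Cl)cc1` is the next member, differing from compound 3 by chloro in place of bromo on an aromatic carbon.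

Among the measured compounds shown here, no measured step exchanges one halogen for another, so the bearing of the known steps is indirect. They show that putting a bromo group at this position, in place of hydrogen or methoxy, lowers the number by a modest amount, and that the position responds to what is placed there. A chloro group in place of bromo is a smaller change than either of those, and a step within the scatter, or a slight rise in the number, is expected.

Compound 4 is therefore estimated at 5800 nM in this assay, with a range from 2500 nM to 13000 nM, which means an expected step of a 1.3-fold higher number from compound 3 to compound 4 (0.11 log units; within the scatter).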

Compound 4, half-maximal inhibitory concentration: 5740 nM
The estimate for compound 4 lay 1.0-fold (0.00 log units) above the measured number; the measured number falls inside the stated range.
By their numbers in this assay, from the lowest: compounds 3 and 4 (each within the scatter of the next); then compounds 1 and 2 (each within the scatter of the next).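

In this assay, the change from 4-bromophenyl to 4-chlorophenyl gives a 1.3-fold higher number from compound 3 to compound 4 (0.11 log units; within the scatter), so this position does not separate these two halogens. The lower number seen earlier with bromo is therefore not unique to bromo: chloro also gives a 2.6-fold lower number from compound 1 to compound 4 (0.41 log units; beyond the scatter) and a 3.3-fold lower number from compound 2 to compound 4 (0.52 log units; beyond the scatter), placing both halogens apart from hydrogen and methoxy among these four compounds. Nothing available explains this grouping. The compounds shown leave open whether fluoro or iodo would fall with chloro and bromo, and whether an amine or a carboxylic acid at this position would stay with hydrogen and methoxy. They also leave open whether the halogen effect would persist if the shared core were changed elsewhere.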